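Swapping the five-membered ring on the shared core

The compounds below may be only part of what the source reports. "The series", "measured", "known", "first", "only" and "open" are said of these compounds alone.

Measured so far:
- Compound 1 `CC1(C)CC(NC(=O)c2ccc(Nc3ncc([N+](=O)[O-])c(N4CCN(c5ccc(F)cc5)CC4)n3)cc2)CC(C)(C)N1[O]`: 13100 nM
- Compound 2 `Cc1cc(Nc2nc(Nc3ccc(C(=O)NC4CC(C)(C)N([O])C(C)(C)C4)cc3)ncc2[N+](=O)[O-])no1`: 7360 nM

In a functional assay on HepG2 cells (Homo sapiens) for antiproliferative activity, read by MTT assay, with a stated time of 48 h (on this read-out higher numbers stand for weaker inhibition and lower numbers for stronger inhibition), compound 2 gives the lowest of the two numbers, and compound 1 sits a short distance away with a gap that lies within the scatter. Compound 3 `CCOC(=O)Cc1csc(Nc2nc(Nc3ccc(C(=O)NC4CC(C)(C)N([O])C(C)(C)C4)cc3)ncc2[N+](=O)[O-])n1` differs from compound 2 by one change: 4-((ethoxycarbonyl)methyl)-1,3-thiazol-2-yl in place of 5-methyl-1,2-oxazol-3-yl on a nitrogen on an aromatic ring. Among the compounds with values here, with no measured pair showing this kind of change, no step beyond the scatter is expected in either direction, and the value of compound 3 is estimated at 7000 nM, in the range 2500 nM to 20000 nM, which means an expected step of a 1.1-fold lower number from compound 2 to compound 3 (0.02 log units; within the scatter).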

Compound 3, half-maximal inhibitory concentration: 26400 nM
Beside the measured number, compound 3's estimate is 3.8-fold (0.58 log units) below it; the measured number lies above the stated range.
By their numbers in this assay, from the lowest: compounds 2, 1 and 3 (each within the scatter of the next, the first and the last beyond it).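

This position is not indifferent to the group it carries: in this assay, 4-((ethoxycarbonyl)methyl)-1,3-thiazol-2-yl in place of 5-methyl-1,2-oxazol-3-yl on the nitrogen gives a 3.6-fold higher number from compound 2 to compound 3 (0.55 log units; beyond the scatter) and so weaker inhibition. This single change replaces the ring and also brings in the ester side chain. Nothing available explains the step.

The compounds shown leave open whether the ring or the side chain accounts for the step. A plain 1,3-thiazol-2-yl or a carboxylic acid in place of the ethyl ester would help separate the two.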